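This account rests on a few compounds, and the source may have more. Where it says the series, first, only, none or still open, it means among the compounds named here.

Going by the values given here, in a functional assay on MDA-MB-231 cells (Homo sapiens) for inhibition, read by MTT assay, with a stated time of 72 h (on this read-out higher numbers stand for weaker inhibition and lower numbers for stronger inhibition), compound 1 `COc1ccccc1-c1csc2cnc(Nc3ccc(C(=O)NCC4CCNCC4)c(F)c3)nc12` gives 1530 nM, the higher of the two numbers so far and therefore the weaker inhibition. Compound 2 `COc1ccccc1-c1csc2cnc(Nc3ccc(C(=O)NC4CCNCC4)cc3)nc12` gives 110 nM, a gap beyond the usual scatter, but these two compounds differ in more than one place, so the gap cannot be pinned on any single group. Compound 3 `COc1ccccc1-c1csc2cnc(Nc3ccc(C(=O)NC4CCOCC4)c(F)c3)nc12` keeps the core of compound 1 and changes only the group on the amide-type nitrogen, with oxan-4-yl in place of (piperidin-4-yl)methyl on an amide-type nitrogen. Among the compounds with values here, no measured pair shows this exchange, so any forecast is loose. Compound 1, at 1530 nM, is the closest guide, and no clear move in either direction is expected. The expected step is a 1.2-fold lower number from compound 1 to compound 3 (0.07 log units; within the scatter), which would lie within the scatter. For compound 3, the estimated value is 1300 nM, with a likely range from 300 nM to 5000 nM.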

Compound 3, half-maximal inhibitory concentration: 5350 nM
Compound 3: the middle estimate sits 4.1-fold (0.61 log units) below what was measured; measured number above the stated range.
By their numbers in this assay, from the lowest: compound 2; then compound 1; then compound 3.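

In this assay, putting oxan-4-yl in place of (piperidin-4-yl)methyl on the amide-type nitrogen gives a 3.5-fold higher number from compound 1 to compound 3 (0.54 log units; beyond the scatter), so the group at this position does affect the read-out, and this exchange weakens inhibition. Two things change together: the ring nitrogen and its hydrogen-bond donor give way to an oxygen, and the methyl link to the ring is lost, so this single step cannot tell which of them matters. No measured evidence is available that explains the loss.

Compound 2 carries a piperidine ring on the amide nitrogen without the methyl link, but it also lacks the fluorine, so it cannot settle the question. As far as these compounds go, whether (oxan-4-yl)methyl or a plain cyclohexyl group at the same place would behave like compound 1 or like compound 3 remains open.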